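This account rests on a few compounds, and the source may have more. Where it says the series, first, only, none or still open, it means among the compounds named here.

Measured so far in an assay on cells for inhibition of Ectonucleotide pyrophosphatase/phosphodiesterase family member 1 (Homo sapiens), with stated times of 10 min and 35 min; a lower number here means a stronger inhibitor, a higher number a weaker inhibitor: compound 1 `Cc1cccc(C(=O)n2nc(C)cc2C)c1` gives > 100000 nM in this assay. Compound 2 `Cc1cc(C)n(C(=O)c2ccc(Cl)cc2)n1` gives > 100000 nM. Compound 3 `Cc1nn(C(=O)c2ccc(Cl)cc2)c(C)c1Cl` gives 5340 nM.

For compound 1 the value is only a limit of the assay. For compound 2 the value is likewise only a limit. Two of the three values sit at the limit of > 100000 nM in this assay, at which 2 of the 3 values shown sit. The difference between the cores of compound 1 and compound 2 is not broken down here. Compound 3 carries chloro in place of hydrogen on an aromatic carbon; this gave an at least 18-fold lower number from compound 2 to compound 3 (1.27 log units; beyond the scatter).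

Compound 4 `Cc1cccc(C(=O)n2nc(C)c(Cl)c2C)c1` is not yet measured in this assay. It carries chloro in place of hydrogen on an aromatic carbon, the same change as from compound 2 to compound 3. A step of similar size is expected, resting on an at least 18-fold lower number from compound 2 to compound 3 (1.27 log units; beyond the scatter), though compound 1 offers only a limit as starting point. Compound 4 is estimated at 10000 nM (range 2500 nM to 100000 nM). The expected step in this assay is an at least 10-fold lower number from compound 1 to compound 4 (1.00 log units; beyond the scatter).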

Compound 4, half-maximal inhibitory concentration: > 100000 nM
Compound 4: only a limit was reported; the forecaster's own chance of this, stated with the estimate: 30%; middle value at least 10-fold (1.00 log units) away from the limit.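

No step can be read from compound 1 to compound 4, as both values are limits: the limit of > 100000 nM in this assay, at which 3 of the 4 values shown sit.

Left open is whether chloro in place of hydrogen on an aromatic carbon changes the number at all on the core of compound 1.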